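Working notes: the step from compound 3 to compound 4

This account rests on a few compounds, and the source may have more. Where it says the series, first, only, none or still open, it means among the compounds named here.

compound 1 `C/C(=N\O)c1ccc2[nH]c(-c3ccc(Cl)cc3)nc2c1` gives 33000 nM
compound 2 `C/C(=N\NC(N)=O)c1ccc2[nH]c(-c3ccc(Cl)cc3)nc2c1` gives > 100000 nM (a limit)
compound 3 `C/C(=N\NC(N)=S)c1ccc2[nH]c(-c3ccc(Cl)cc3)nc2c1` gives > 100000 nM (a limit)

In an ADME assay on BHK-21 cells (Mesocricetus auratus) for cytotoxicity, read by MTT assay (on this read-out lower numbers stand for higher toxicity in this test and higher numbers for lower toxicity in this test), compound 3 stands at the limit of > 100000 nM in this assay, at which 2 of the 3 values shown sit, and has no number. Compound 4 `C/C(=N\NC(N)=S)c1ccc2[nH]c(C3CCCCC3)nc2c1` carries cyclohexyl in place of 4-chlorophenyl on an aromatic carbon between two ring nitrogen atoms.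

Three steps were measured: an at least 3.0-fold higher number from compound 1 to compound 2 (0.48 log units; beyond the scatter) and an at least 3.0-fold higher number from compound 1 to compound 3 (0.48 log units; beyond the scatter) on a double-bonded nitrogen, and a step that the two limits leave unreadable from compound 2 to compound 3 on an amine nitrogen. None changes the group on that aromatic carbon, so none gives a size for this change.

The expected step is an at least 1.2-fold lower number from compound 3 to compound 4 (0.09 log units; that floor lies within the scatter) and its direction, if readable at all, is toward a lower number. For compound 4 the estimated value is 80000 nM with an expected range of 25000 nM to 200000 nM for now.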

Compound 4, half-maximal cytotoxic concentration: 24000 nM
Beside the measured number, compound 4's estimate is 3.3-fold (0.52 log units) above it; the whole stated range lies above it.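

In this assay, the group on the aromatic carbon between two ring nitrogen atoms proves to matter: cyclohexyl in place of 4-chlorophenyl gives an at least 4.1-fold lower number from compound 3 to compound 4 (0.61 log units; beyond the scatter), which means higher toxicity in this test. The group on the double-bonded nitrogen is the same in both compounds, so that group alone does not hold a compound at the limit. The size of this step is only a floor, as compound 3 has a limit and no number: the limit of > 100000 nM in this assay, at which 2 of the 4 values shown sit.

The compounds shown leave open whether the lower number follows from losing the chlorine or the aromatic ring. An unsubstituted phenyl on this carbon would separate the two.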